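The compounds below may be only part of what the source reports. "The series", "measured", "known", "first", "only" and "open" are said of these compounds alone.

Compound 1 `CC(C)Oc1cccc(-c2ccc(C(=O)N(Cc3cccc(OCCCCCC(=O)O)c3)C(C)C)cc2)c1`, in an ADME assay on BJ cells (Homo sapiens) for cytotoxicity, read by CellTiter-Glo and resazurin assay, with a stated time of 72 h; a lower number here means that less compound is needed, a higher number that more compound is needed for the effect: > 26000 nM
Compound 2 `CC(C)N(Cc1cccc(OCCCCCC(=O)O)c1)C(=O)c1ccc(-c2ccc3c(c2)OCCO3)cc1`, in this assay: > 21900 nM

The value of compound 1 is a limit of the assay, not a number. The value of compound 2 is likewise only a limit, so compound 2 stands at the edge of what this assay reports. Within the data shown here, the single measured step, a step that the two limits leave unreadable from compound 1 to compound 2, has no readable size, as the limits the limit of > 21900 nM in this assay, at which 1 of the 2 values shown sits, and the limit of > 26000 nM in this assay, at which 1 of the 2 values shown sits, show. Compound 3 `CC(C)N(Cc1cccc(OCCCCCC(=O)O)c1)C(=O)c1ccc(-c2cccc(Cl)c2)cc1` differs from compound 2 by 3-chlorophenyl in place of 2,3-dihydro-1,4-benzodioxin-6-yl on an aromatic carbon. With no readable step to lean on, compound 3 is expected to show a step that the limit leaves unreadable from compound 2 to compound 3 that stays within the scatter. The value of compound 3 is estimated at 25000 nM, between 10000 nM and 60000 nM, most likely again reported as a limit.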

Compound 3, half-maximal effective concentration: > 21900 nM
Compound 3 gave a limit, no number; the forecaster's own chance of this, stated with the estimate: 75%; the middle value lies beyond the limit too.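

In this assay compound 3 gives > 21900 nM, a limit and not a number, so its steps from compound 1 and compound 2 cannot be read. The compounds shown leave open what concentration any of the three would need for the effect.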